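Swapping the Group on the Ring Nitrogen of Compound 3

A few compounds are considered here, and "the series" means these few. Any claim that something is new, unique, unknown or untested is made for them only; others in the source may bear on it.

Of the compounds shown here, three sharing one core have been tested in a functional assay on the whole organism (strain Kunming) for inhibition, with Mus musculus as the target, with a stated time of 1 h, at a dose of 40 mg/kg by the oral route; on this read-out lower numbers stand for less inhibition and higher numbers for more inhibition at the one dose given (going by the name of the read-out). Compound 1 `O=C(/C=C/c1ccccc1)c1ccc(N2CCN(c3ccc([N+](=O)[O-])cc3)CC2)cc1` gives 55.4%, compound 2 `COc1ccc(/C=C/C(=O)c2ccc(N3CCN(c4ccc(C)cc4C)CC3)cc2)cc1OC` gives 48.5%, and compound 3 `Cc1ccc(N2CCN(c3ccc(C(=O)/C=C/c4ccc(Cl)cc4)cc3)CC2)c(C)c1` gives 25.7%, the lowest of the three, with compound 2 above it beyond the scatter and compound 1 further still. Among the measured compounds shown here, the only comparison that changes one place is a number 22.8 percentage points lower from compound 2 to compound 3 (beyond the scatter), which alters the group on the double-bonded chain carbon. Compound 4 `O=C(/C=C/c1ccc(Cl)cc1)c1ccc(N2CCN(S(=O)(=O)c3ccc(Cl)cc3)CC2)cc1` differs from compound 3 elsewhere: (4-chlorophenyl)sulfonyl in place of 2,4-dimethylphenyl on an amine nitrogen in a ring. For the measured compounds named here, no measured pair changes the group on that ring nitrogen alone; compound 1 and compound 2 differ there but also at the double-bonded chain carbon, so their two values cannot be split into parts. Going by the values given here, the one known step therefore does not bear on this change, and the direction for compound 4 is open. Compound 4 is expected to land near 35%, within 10% to 65%. The expected change is a number 9.3 percentage points higher from compound 3 to compound 4 (within the scatter), which may well fall within the scatter.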

Compound 4, a percentage reported as inhibition, in the whole organism at one dose (the size of the read-out at that dose, not a potency): 56.6%
Estimate against measurement, compound 4: 21.6 percentage points below, within the range that was stated.
By their numbers in this assay, from the lowest: compound 3; then compounds 2, 1 and 4 (each within the scatter of the next).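

Changing the group on the amine nitrogen in a ring moves the result in this assay by a large amount: a number 30.9 percentage points higher from compound 3 to compound 4 (beyond the scatter). Among the compounds shown here, this is the first measured step that isolates this position, showing that it can shift the read-out without any change at the double-bonded chain carbon. Both groups hold one six-membered aromatic ring of carbon only, but the entering group also brings a sulfonyl link with 2 hydrogen-bond acceptors, and no measurement available here explains the rise.

The compounds shown do not separate the effect of the sulfonyl link from that of the groups on the aromatic ring, and whether a methylsulfonyl or benzoyl group would give a similar result stays open. It is also unknown whether the step holds with a chain group other than 4-chlorophenyl.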